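Hydroxy(phenyl)methyl for phenyl on a cytotoxicity scaffold

This account rests on a few compounds, and the source may have more. Where it says the series, first, only, none or still open, it means among the compounds named here.

Measured compounds:
- compound 1 `C[Si](C)(C)C#Cc1c[nH]c(=O)[nH]c1=O`: 124000 nM
- compound 2 `O=c1[nH]cc(C#CC2CCCCC2)c(=O)[nH]1`: 62800 nM
- compound 3 `O=c1[nH]c(=O)n([C@@H]2O[C@H](CO)[C@@H](O)[C@H]2O)cc1C#Cc1ccccc1`: 1200 nM

The read-out throughout is an ADME assay on MRC5 cells (Homo sapiens) for cytotoxicity, read by MTT assay; a lower number here means that less compound is tolerated, a higher number that more compound is tolerated. Compound 3 stands lowest of the three measured numbers: against compound 2 it sits well apart, and against compound 1 it sits even further apart, both gaps lying beyond the usual scatter. Compound 3 is therefore the least tolerated of the three compounds on hand.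

Compound 4 `O=c1[nH]c(=O)n([C@@H]2O[C@H](CO)[C@@H](O)[C@H]2O)cc1C#CC(O)c1ccccc1` is the next compound, not yet measured. Its change from compound 3 is hydroxy(phenyl)methyl in place of phenyl on a triple-bonded carbon. For the measured compounds named here, no measured pair here shows a change of this kind, so the direction of the step is open. A modest rise is expected, with a hydroxy(phenyl)methyl group in place of phenyl, but the expected step from compound 3 to compound 4 of a 2.1-fold higher number from compound 3 to compound 4 (0.32 log units; beyond the scatter) could also fall within the scatter. For compound 4 the expected value is 2500 nM, with a range from 800 nM to 8000 nM.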

Compound 4, half-maximal cytotoxic concentration: 900 nM
Beside the measured number, compound 4's estimate is 2.8-fold (0.44 log units) above it; the range from low to high includes it.
By their numbers in this assay, from the lowest: compounds 4 and 3 (each within the scatter of the next); then compounds 2 and 1 (each within the scatter of the next).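

In this assay, placing hydroxy(phenyl)methyl in place of phenyl on a triple-bonded carbon gives a 1.3-fold lower number from compound 3 to compound 4 (0.12 log units; within the scatter), so compound 3 and compound 4 cannot be told apart in this read-out. For the compounds shown here, this is the first measured pair here that differs in only one place, and it gives the first direct reading of a change at this position. The entering group keeps the aromatic ring of carbon and adds a hydrogen-bond donor and a hydrogen-bond acceptor, yet the result stays within the usual scatter, and no supporting measurement is available to explain it.

As far as these compounds go, the two compounds both carry an aromatic ring on this side of the triple bond, so what the ring itself contributes remains open. An amine, a carboxylic acid or a longer chain at the same place could show whether this position tolerates a larger departure from phenyl.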